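From sec-butyl to phenyl on a growth inhibitor

The compounds below may be only part of what the source reports. "The series", "measured", "known", "first", "only" and "open" are said of these compounds alone.

In a functional assay on OCI-Ly3 cells (Homo sapiens) for inhibition, read by CellTiter-Glo, with stated times of 48 h and 96 h (a lower number here means a stronger inhibitor of growth, a higher number a weaker inhibitor of growth), compound 1 `CCC(=O)[C@H](CCCNC(=N)N)NC(=O)[C@@H]1CCCN1C(=O)[C@@H](NC(=O)[C@H](CC(C)C)NC(=O)OCc1ccccc1)C(C)C` is reported as > 20000 nM which is a limit of the assay and not a number.

Within the data shown here, compound 2 `CC[C@H](C)[C@H](NC(=O)OCc1ccccc1)C(=O)N1CCC[C@H]1C(=O)N[C@@H](CCCNC(=N)N)C(=O)CF` gives 2440 nM as the only true number so far, so there is no second number to rank it against.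

Compound 3 `N=C(N)NCCC[C@H](NC(=O)[C@@H]1CCCN1C(=O)[C@@H](NC(=O)OCc1ccccc1)c1ccccc1)C(=O)CF` has phenyl in place of sec-butyl on a saturated chain carbon bound to an amide-type nitrogen and a carbonyl carbon. Among the measured compounds shown here, no measured pair shows what this kind of swap does, so compound 2 at 2440 nM is the only anchor for a forecast. No change beyond the usual scatter is expected, with a slight lean towards weaker inhibition, as the estimated step (a 1.2-fold higher number from compound 2 to compound 3 (0.09 log units; within the scatter)) shows. Compound 3 is expected at 3000 nM with an estimated range from 800 nM to 12000 nM in this assay once it is tested.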

Compound 3, concentration for 50% growth inhibition: 8050 nM
Compound 3: the middle estimate sits 2.7-fold (0.43 log units) below what was measured; measured number inside the range.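

In this assay, phenyl in place of sec-butyl on a saturated chain carbon bound to an amide-type nitrogen and a carbonyl carbon gives a 3.3-fold higher number from compound 2 to compound 3 (0.52 log units; beyond the scatter). Among these compounds, this is the first measured sign that the group at this position matters: here, the swap to phenyl goes with weaker growth inhibition, although neither group carries hydrogen-bond donors or acceptors. Among the compounds shown here, compound 1 remains a limit of the assay and not a number, so it adds no measured step at this position: the limit of > 20000 nM in this assay, at which 1 of the 3 values shown sits.

This single step cannot separate the effect of gaining an aromatic ring from that of losing the sec-butyl group and its defined stereocentre. A cyclohexyl group at the same carbon would bear on that question, since it has a ring of six carbons but is not aromatic.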